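The source may hold more compounds than are shown below. What is called first, only, known or untested is meant among the compounds shown, and "the series" means these compounds.

Working notes on the series. Compound 1 `OC[C@H]1O[C@@H](n2cnc3c(NCc4ccccc4Cl)ncnc32)[C@H](O)[C@@H]1O` carries a 2-chlorobenzyl group on the shared core. In a functional assay on HOS cells (Homo sapiens) for antiproliferative activity, with a stated time of 72 h (a higher number here means a weaker inhibitor, a lower number a stronger inhibitor), compound 1 gives > 166000 nM, which is a limit of the assay rather than a number. Compound 2 `OC[C@H]1O[C@@H](n2cnc3c(NCc4ccc(Br)cc4)ncnc32)[C@H](O)[C@@H]1O` gives > 166000 nM in this assay, also only a limit. Compound 3 `Cc1cccc(CNc2ncnc3c2ncn3[C@@H]2O[C@H](CO)[C@@H](O)[C@H]2O)c1` gives > 166000 nM in this assay, again a limit. Among the compounds with values here, every value so far sits at the limit of > 166000 nM in this assay, at which 3 of the 3 values shown sit, so compound 1 stands nowhere distinguishable from compounds 2 and 3. The steps a step that the two limits leave unreadable from compound 1 to compound 2, a step that the two limits leave unreadable from compound 1 to compound 3 and a step that the two limits leave unreadable from compound 2 to compound 3 are all unreadable because of the limit of > 166000 nM in this assay, at which 3 of the 3 values shown sit.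

Compound 4 `OC[C@H]1O[C@@H](n2cnc3c(NCc4ccc(Cl)c(Cl)c4)ncnc32)[C@H](O)[C@@H]1O` is not yet measured in this assay. It differs from compound 1 by 3,4-dichlorophenyl in place of 2-chlorophenyl on a saturated chain carbon bound to a nitrogen on an aromatic ring. The measured steps that bear on a change at this place are the three above, and none of them gives a readable size, so no direction beyond the scatter can be expected. Compound 4 is therefore expected to sit again at the limit, a step that the limit leaves unreadable from compound 1 to compound 4, giving an estimate of 200000 nM with a range from 100000 nM to 400000 nM.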

Compound 4, half-maximal inhibitory concentration: > 166000 nM
Compound 4: only a limit was reported; the forecaster's own chance of this, stated with the estimate: 85%; the middle value does not contradict the limit.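

The steps from compound 4 to compounds 1, 2 and 3 cannot be read in this assay because each value is only a limit: the limit of > 166000 nM in this assay, at which 4 of the 4 values shown sit.

The compounds shown leave open how these four benzyl groups on the shared core rank against one another in this assay.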